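Swapping the methoxyphenyl for a pyrrole on the exocyclic carbon

This account rests on a few compounds, and the source may have more. Where it says the series, first, only, none or still open, it means among the compounds named here.

Compound 1 `CCOC(=O)C1=C(Nc2ccccc2)S/C(=C\c2ccc(OC)cc2)C1=O` is one of three analogues sharing a core measured in a functional assay on JAR cells (Homo sapiens) for inhibition, read by MTT assay, with a stated time of 72 h, tested at 10 uM (on this read-out higher numbers stand for more inhibition at the one concentration tested (going by the name of the read-out) and lower numbers for less inhibition), where compound 1 gives 32.9%. Compound 2 `CCOC(=O)C1=C(Nc2ccc(OC)cc2)S/C(=C\c2ccc[nH]2)C1=O` gives 27.6% and compound 3 `CCOC(=O)C1=C(Nc2ccc(C(F)(F)F)cc2)S/C(=C\c2ccc[nH]2)C1=O` gives 38.5%. Compound 1 thus stands second of the three, and both its gaps, to compound 2 and to compound 3, lie within the scatter. The one clean step shown, a number 10.9 percentage points higher from compound 2 to compound 3 (beyond the scatter), concerns a change on the aniline and not on the exocyclic arm.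

Compound 4 `CCOC(=O)C1=C(Nc2ccccc2)S/C(=C\c2cc[nH]c2)C1=O` differs from compound 1 by 1H-pyrrol-3-yl in place of 4-methoxyphenyl on a double-bonded chain carbon bound to a double-bonded ring carbon. Among the compounds with values here, no measured pair isolates this change. Compounds 2 and 3 do carry a pyrrole on the same chain carbon, joined through another ring carbon and paired with different aniline substituents, and their values bracket that of compound 1 without exceeding the scatter on either side. The pyrrole-bearing analogues therefore give no sign of a shift beyond the scatter, and none is expected from compound 1 to compound 4, so a number 1.9 percentage points lower from compound 1 to compound 4 (within the scatter) is taken as essentially flat. Compound 4 is accordingly estimated at 31%, with a range from 18% to 44%.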

Compound 4, a percentage reported as inhibition, at one concentration (the size of the read-out at that concentration, not a potency): 19.5%
For compound 4 the middle estimate is 11.5 percentage points above the measured one, and the stated range covers the measured number.
By their numbers in this assay, from the lowest: compounds 4, 2, 1 and 3 (each within the scatter of the next, the first and the last beyond it).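

Within the data shown here, compound 4 gives the first pair in which only the group on the double-bonded chain carbon bound to a double-bonded ring carbon changes, and in this assay the swap of 4-methoxyphenyl for 1H-pyrrol-3-yl gives a number 13.4 percentage points lower from compound 1 to compound 4 (beyond the scatter). Among these compounds, this place on the shared core therefore responds to the group it carries, a point that the earlier compounds could not establish, as their one clean step concerned a change on the aniline. The change itself is a composite one, replacing a six-membered aromatic ring of carbon only with a five-membered aromatic ring with one hetero atom, and nothing available bears on why the number falls.

The compounds shown leave open whether the drop follows the loss of the methoxy group or the change of ring, a question that an unsubstituted phenyl or a thiophene on the same carbon, with the aniline of compound 1 kept, would help to separate. They also leave open whether the effects at the aniline and on this chain carbon add up, since no pair shown varies the two together from a common compound.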